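A few compounds are considered here, and "the series" means these few. Any claim that something is new, unique, unknown or untested is made for them only; others in the source may bear on it.

Of the compounds shown here, three that share one core have been tested so far in a functional assay on MGC-803 cells (Homo sapiens) for cytotoxicity, read by MTT assay, with a stated time of 48 h; on this read-out higher numbers stand for weaker inhibition and lower numbers for stronger inhibition. Compound 1 (`CCC(=O)N1N=C(C)CC1c1cc(Br)ccc1O`) gives 50300 nM, compound 2 (`CCC(=O)N1N=C(C)CC1c1cc(Br)cc(Br)c1O`) gives 38600 nM, and compound 3 (`CC1=NN(C(=O)COc2ccc(Cl)cc2)C(c2cc(Br)cc(Br)c2O)C1`) gives 50000 nM. Compound 2 does not stand apart from the other two. Placing a bromo in place of hydrogen on an aromatic carbon gives a 1.3-fold lower number from compound 1 to compound 2 (0.11 log units; within the scatter), so that change leaves the number within the noise of repeated measurements.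

Compound 4 (`CC1=NN(C(=O)c2ccc(C)cc2)C(c2cc(Br)cc(Br)c2O)C1`) has not yet been measured. It differs from compound 2 by one change: 4-methylphenyl in place of ethyl on a carbonyl carbon. In words, this is 4-methylphenyl in place of ethyl on a carbonyl carbon. The closest guide is the change from methyl to 4-chlorophenoxy on a saturated chain carbon bound to a carbonyl carbon, which gives a 1.3-fold higher number from compound 2 to compound 3 (0.11 log units; within the scatter). Among the compounds with values here, that change is made at a different place, however, and no measured compound carries a ring directly on the carbonyl carbon, so the guide is only partial. With both measured steps inside the scatter, no clear direction can be expected. The expected outcome is a 1.1-fold lower number from compound 2 to compound 4 (0.04 log units; within the scatter), a step no larger than the scatter. Compound 4 is estimated at 35000 nM, with an expected range from 14000 nM to 75000 nM.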

Compound 4, half-maximal inhibitory concentration: 56500 nM
The estimate for compound 4 lay 1.6-fold (0.21 log units) below the measured number, and the stated range covers the measured number.
By their numbers in this assay, from the lowest: compounds 2, 3, 1 and 4 (each within the scatter of the next).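

In this assay, putting 4-methylphenyl in place of ethyl on the carbonyl carbon, whose other neighbour is the amide-type nitrogen in a ring, gives a 1.5-fold higher number from compound 2 to compound 4 (0.17 log units; within the scatter). Within the data shown here, compound 3 holds its aromatic ring on a saturated chain carbon bound to the carbonyl carbon, whereas compound 4 holds one on the carbonyl carbon itself, so this is the first reading for a ring at that place, and even this larger group leaves the step inside the scatter. No measured information is available to explain this result.

The compounds shown do not separate the ring from its methyl, since a plain phenyl on the carbonyl carbon would be needed to read the contribution of each. Nor do they show whether any group at this place can give a step beyond the scatter: a chain ending in an amine or a carboxylic acid, for example, would put a very different kind of group there and test how far the number can be moved in either direction.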